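Swapping the aryl group on a fused two-ring core

The source may report more compounds than this note shows. Statements on the series, on what has been measured and on what is new or still open speak of the compounds shown alone.

Compound 1 `COc1cc(-c2cc3nccc(-c4cc(OC)c(OC)c(OC)c4)n3n2)cc(OC)c1OC`: in a functional assay on B16-F0 cells (Mus musculus) for inhibition, read by CCK-8 assay, with a stated time of 48 h (a higher number here means a weaker inhibitor, a lower number a stronger inhibitor), compound 1 gives > 10000 nM, which is a limit of the assay and not a number.
Compound 2 `COc1cc(-c2ccnc3cc(-c4ccc(C(F)(F)F)cc4)nn23)cc(OC)c1OC`: in this assay compound 2 gives 1770 nM.
Compound 3 `CCOC(=O)c1ccc(-c2cc3nccc(-c4cc(OC)c(OC)c(OC)c4)n3n2)cc1`: in this assay compound 3 gives > 10000 nM, again a limit and not a number.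

Among the three measured compounds, compound 2 is the only one with a real number in this assay; the other two values are limits. Compound 4 `COc1ccc(-c2cc3nccc(-c4cc(OC)c(OC)c(OC)c4)n3n2)cc1F` differs from compound 2 in one place: 3-fluoro-4-methoxyphenyl in place of 4-(trifluoromethyl)phenyl on an aromatic carbon.

For the measured compounds named here, one measured step bears on this change, the exchange of the same aryl group in the same place: an at least 5.6-fold higher number from compound 2 to compound 3 (0.75 log units; beyond the scatter). Beyond that, compound 1 and compound 3 both sit at the limit of > 10000 nM in this assay, at which 2 of the 3 values shown sit, so of the three aryl groups tried on this carbon, only the 4-(trifluoromethyl)phenyl of compound 2 gave a number. Compound 4 carries a methoxy, as compound 1 does, and a single fluorine, as compound 2 does through its trifluoromethyl. On this basis a weaker inhibitor than compound 2 is expected, with the step of a 3.4-fold higher number from compound 2 to compound 4 (0.53 log units; beyond the scatter). Compound 4 is estimated at 6000 nM, with a range from 2000 nM to 20000 nM, and a fair chance that only a limit is reported.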

Compound 4, half-maximal inhibitory concentration: 3950 nM
For compound 4 the middle estimate is 1.5-fold (0.18 log units) above the measured one, within the range that was stated.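

A second aryl group now gives a real number on this carbon, so the 4-(trifluoromethyl)phenyl group is no longer the only one that does. In this assay, exchanging it for 3-fluoro-4-methoxyphenyl gives a 2.2-fold higher number from compound 2 to compound 4 (0.35 log units; beyond the scatter), and since a higher number means a weaker inhibitor, this is a modest loss, though one beyond the scatter. The trifluoromethyl group can therefore be given up here while the inhibition stays measurable, which sets compound 4 apart from the two compounds that still give no number: the limit of > 10000 nM in this assay, at which 2 of the 4 values shown sit.

The entering group brings a methoxy and a fluorine together, so this single step cannot show what each contributes, and a ring carrying only the methoxy or only the fluorine would be needed to separate them. The compounds shown also leave open how an amine or a carboxylic acid on this aryl ring would behave, and whether any group on this carbon can give a lower number than compound 2 does.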